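The compounds below may be only part of what the source reports. "The series", "measured", "known", "first", "only" and "open" are said of these compounds alone.

Of the compounds shown here, three sharing one acid-bearing core have been measured in an ADME assay on HMVE cells (Homo sapiens) for inhibition, read by resazurin assay, with a stated time of 72 h; a higher number here means a weaker inhibitor, a lower number a stronger inhibitor. Compound 1 `Cc1cc(C)c(-c2cc(-c3ccc4cc(C(=O)O)ccc4c3C)ccc2O)c(C)c1` is reported only as a limit, > 500 nM. Compound 2 `CC1(C)CC(c2cc(-c3ccc4cc(C(=O)O)ccc4c3)ccc2O)CC(C)(C)C1` gives 500 nM, and compound 3 `Cc1c(-c2ccc(O)c(-c3ccc4c(c3)C(C)(C)CCC4(C)C)c2)ccc2cc(C(=O)O)ccc12` gives 600 nM, so these two numbers lie within the usual scatter of each other. Compound 2 is therefore the reference point, but it cannot be separated from compound 3.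

Compound 4 `O=C(O)c1ccc2cc(-c3ccc(O)c([C@@H]4CC[C@@H]5CCCC[C@H]5C4)c3)ccc2c1` loses the 3,3,5,5-tetramethylcyclohexyl group of compound 2 and takes instead a group with 2 six-membered non-aromatic rings of carbon only, on an aromatic carbon ortho to a hydroxy group: a group of 10 heavy atoms (10 carbon; 2 six-membered non-aromatic rings of carbon only) in place of a group of 10 heavy atoms (10 carbon; one six-membered non-aromatic ring of carbon only), on an aromatic carbon. Going by the values given here, no measured pair isolates a change of this kind. The expectation rests on compound 3, which carries a different carbon-only group, differs in more than one place, and still gives 600 nM. A small move towards a higher number in this assay is expected, possibly none beyond the scatter, and the estimated step is a 1.2-fold higher number from compound 2 to compound 4 (0.08 log units; within the scatter). For compound 4 the estimated value is 600 nM, with an expected range of 250 nM to 1500 nM.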

Compound 4, half-maximal inhibitory concentration: > 500 nM
Compound 4: a limit, no number; the forecaster's own chance of this, stated with the estimate: 15%; the middle value is on the limit's open side.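

At the place on an aromatic carbon ortho to a hydroxy group, putting the group with 2 six-membered non-aromatic rings of carbon only where 3,3,5,5-tetramethylcyclohexyl stood gives, in this assay, a number no lower from compound 2 to compound 4 (the limit leaves the size open). Going by these compounds alone, this is the first comparison here that differs in one place, and it shows that this change of ring count, at the same count of heavy atoms, brings no gain the assay can register. For compound 4 the reading is a limit and not a number, and the size of the step stays unreadable because of where the readings stop: the limit of > 500 nM in this assay, at which 2 of the 4 values shown sit.

The compounds shown leave open how far compound 4 actually lies from compound 2. They also leave open whether an amine or a hydroxymethyl group at this place would give a clearly lower number.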